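This account rests on a few compounds, and the source may have more. Where it says the series, first, only, none or still open, it means among the compounds named here.

Measured compounds in a functional assay on HEK293 cells for agonist activity at Bombesin receptor subtype-3 (Mus musculus), read by luminescence and calcium flux, with a stated time of 10 min; on this read-out lower numbers stand for an effect already at smaller amounts and higher numbers for an effect only at larger amounts of compound: compound 1 `CCC(C)(C)Cc1c[nH]c(CCc2ccc(-n3cccn3)cc2)n1` gives 9 nM; compound 2 `CCC(C)(C)Cc1c[nH]c(CCc2ccc(-c3cnccn3)cc2)n1` gives 11 nM.

Among these two numbers compound 2 holds the higher one, with compound 1 nearest, since a 1.2-fold higher number from compound 1 to compound 2 (0.09 log units; within the scatter). Compound 3 `CCC(C)(C)Cc1c[nH]c(CCc2ccc(-c3cccc(N)n3)cc2)n1` is not yet measured; its change from compound 2 is 6-aminopyridin-2-yl in place of pyrazin-2-yl on an aromatic carbon. Within the data shown here, the only measured step that bears on it, a 1.2-fold higher number from compound 1 to compound 2 (0.09 log units; within the scatter), exchanged the aryl substituent at the same place and stayed within the scatter, so the step to compound 3 is expected to be small, a 1.1-fold higher number from compound 2 to compound 3 (0.04 log units; within the scatter). Compound 3 is therefore estimated at 12 nM, between 4 nM and 40 nM.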

Compound 3, half-maximal effective concentration: 3.9 nM
Beside the measured number, compound 3's estimate is 3.1-fold (0.49 log units) above it; measured number below the stated range.
By their numbers in this assay, from the lowest: compound 3; then compounds 1 and 2 (each within the scatter of the next).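

In this assay the place on the six-membered aromatic ring of carbon only, para to a large group, proves responsive to the choice of aryl substituent: 6-aminopyridin-2-yl gives a 2.8-fold lower number from compound 2 to compound 3 (0.45 log units; beyond the scatter) and a 2.3-fold lower number from compound 1 to compound 3 (0.36 log units; beyond the scatter) as modest steps that, unlike the earlier exchange, lie beyond the scatter. Unlike pyrazin-2-yl, the entering group carries a hydrogen-bond donor, but this difference alone does not explain the steps. Nothing measured here accounts for them.

The compounds shown leave open whether the steps belong to the amine or to the pyridine ring that carries it. On these data alone, it is also open whether a methylamino or hydroxyl group in place of that amine would give a similar number.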